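A 2,6-Difluorophenyl Swap on a Level Pair

This account rests on a few compounds, and the source may have more. Where it says the series, first, only, none or still open, it means among the compounds named here.

In a functional assay with Homo sapiens as the target (a higher number here means a weaker inhibitor, a lower number a stronger inhibitor), compound 1 (`CC(C)[C@H](NC(=O)COc1cccc2ccccc12)C(=O)N[C@@H](CC(=O)O)C(=O)COc1ccc(C#N)cc1`) gives 26700 nM. For the measured compounds named here, the only other measured compound, compound 2 (`CC(C)[C@H](NC(=O)COc1cccc2ccccc12)C(=O)N[C@@H](CC(=O)O)C(=O)COc1ccc(Oc2ccc(C(F)(F)F)cc2)cc1`), gives 24900 nM, so compound 1 stands level with it. Compound 3 (`CC(C)[C@H](NC(=O)COc1cccc2ccccc12)C(=O)N[C@@H](CC(=O)O)C(=O)COc1c(F)cccc1F`) keeps the core of compound 1 but carries 2,6-difluorophenyl in place of 4-cyanophenyl on an oxygen on a saturated carbon. Going by the values given here, one measured step bears on this change. Putting 4-(trifluoromethyl)phenoxy in place of cyano on an aromatic carbon gave a 1.1-fold lower number from compound 1 to compound 2 (0.03 log units; within the scatter). Among the compounds with values here, no measured compound carries 2,6-difluorophenyl, so this exchange itself is untested. In this assay, no step beyond the usual scatter is therefore expected, though with wide uncertainty. The expected step is a 1.3-fold lower number from compound 1 to compound 3 (0.13 log units; within the scatter). Compound 3 is estimated at 20000 nM, within an expected range of 5000 nM to 40000 nM.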

Compound 3, half-maximal inhibitory concentration: > 100000 nM
Compound 3 ended at the assay's limit; the forecaster's own chance of this, stated with the estimate: 10%; middle value at least 5.0-fold (0.69 log units) away from the limit.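

In this assay compound 3 reads > 100000 nM, which is a limit of the assay and not a number. The earlier pair had stayed level, with a 1.1-fold lower number from compound 1 to compound 2 (0.03 log units; within the scatter), but this result shows that the group on the oxygen on a saturated carbon is not free to vary, since 2,6-difluorophenyl in place of 4-cyanophenyl gives an at least 3.7-fold higher number from compound 1 to compound 3 (0.57 log units; beyond the scatter). The full size of this step stays unknown because compound 3 sits at the limit: the limit of > 100000 nM in this assay, at which 1 of the 3 values shown sits.

The compounds shown do not separate the loss of the nitrile from the arrival of the two fluorines, since both happen in the one exchange. Going by these compounds, whether a plain phenyl on the same oxygen would stand with compound 1 or with compound 3 remains open.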